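Compound 4: 4-methylpiperazin-1-yl in place of hexylamino

The compounds below may be only part of what the source reports. "The series", "measured", "known", "first", "only" and "open" are said of these compounds alone.

Measured in a functional assay on A549 cells (Homo sapiens) for inhibition, read by MTT assay, with a stated time of 48 h; on this read-out higher numbers stand for weaker inhibition and lower numbers for stronger inhibition:
- Compound 1 `COc1ccc(/C=C/c2cc(OC)cc(OC)c2/C=C/C(=O)N2CCCCC2)cc1` gives 10600 nM
- Compound 2 `COc1ccc(/C=C/c2cc(OC)cc(OC)c2/C=C/C(=O)N2CCC(c3ccccc3)CC2)cc1` gives 6690 nM
- Compound 3 `CCCCCCNC(=O)/C=C/c1c(/C=C/c2ccc(OC)cc2)cc(OC)cc1OC` gives 6230 nM

Compound 3 stands within the scatter of both other compounds, with a 1.7-fold lower number from compound 1 to compound 3 (0.23 log units; within the scatter) and a 1.1-fold lower number from compound 2 to compound 3 (0.03 log units; within the scatter). Compound 4 `COc1ccc(/C=C/c2cc(OC)cc(OC)c2/C=C/C(=O)N2CCN(C)CC2)cc1` keeps the shared core but carries 4-methylpiperazin-1-yl in place of hexylamino on a carbonyl carbon. Within the data shown here, no measured step makes this exact exchange. The closest guide is the exchange at the same carbonyl carbon, seen in a 1.7-fold lower number from compound 1 to compound 3 (0.23 log units; within the scatter), while the ring substitution gave a 1.6-fold lower number from compound 1 to compound 2 (0.20 log units; within the scatter). Both lie within the scatter, so no step beyond the scatter is expected in this assay. Compound 4 has a ring on the carbonyl carbon, as does compound 1 with 10600 nM, so the expectation leans slightly toward that value. The expected change is a 1.4-fold higher number from compound 3 to compound 4 (0.16 log units; within the scatter). For compound 4 the estimated value is 9000 nM, with an expected range of 4500 nM to 20000 nM.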

Compound 4, half-maximal inhibitory concentration: 4510 nM
For compound 4 the middle estimate is 2.0-fold (0.30 log units) above the measured one; low and high end bracket the measured number.
By their numbers in this assay, from the lowest: compounds 4, 3, 2 and 1 (each within the scatter of the next, the first and the last beyond it).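

In this assay, among these compounds, the exchange of piperidin-1-yl for 4-methylpiperazin-1-yl on the carbonyl carbon gives the only step in this set beyond the scatter, a modest one (a 2.4-fold lower number from compound 1 to compound 4 (0.37 log units; beyond the scatter)), so a ring at this place does not by itself keep the number near that of compound 1. The other two exchanges stay within the scatter (a 1.4-fold lower number from compound 3 to compound 4 (0.14 log units; within the scatter)) and (a 1.5-fold lower number from compound 2 to compound 4 (0.17 log units; within the scatter)), so hexylamino, 4-phenylpiperidin-1-yl and 4-methylpiperazin-1-yl cannot be told apart here. No supporting evidence is available to explain the modest step.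

The compounds shown leave open how piperazin-1-yl without its methyl, or morpholin-4-yl, would read on the same carbonyl carbon. They also leave open whether an amine with a chain longer than hexylamino would stand apart from compound 3.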